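This account rests on a few compounds, and the source may have more. Where it says the series, first, only, none or still open, it means among the compounds named here.

Working notes on the series. In a functional assay on cells for antagonist activity at C-C chemokine receptor type 4 (Homo sapiens), read by fluorescence and calcium flux, with stated times of 2.5 s and 45 s (on this read-out higher numbers stand for weaker inhibition and lower numbers for stronger inhibition), compound 1 `Cc1nn([C@H](C)c2ccc(Cl)cc2Cl)c2nc(N3CC[C@H](N4CCCC4)[C@H](C)C3)cnc12` gives 69 nM and compound 2 `Cc1nn([C@H](C)c2ccc(Cl)cc2Cl)c2nc(N3CC[C@H](N4CCC[C@H]4CO)[C@H](C)C3)cnc12` gives 32 nM; compound 2 holds the lower of the two numbers, the step being a 2.2-fold lower number from compound 1 to compound 2 (0.33 log units; beyond the scatter). Compound 3 `Cc1nn([C@H](C)c2ccc(Cl)cc2Cl)c2nc(N3CC[C@H](N4CCCCCC4)[C@H](C)C3)cnc12` carries azepan-1-yl in place of 2-(hydroxymethyl)pyrrolidin-1-yl on a saturated ring carbon. Going by the values given here, the one step that bears on this is a 2.2-fold lower number from compound 1 to compound 2 (0.33 log units; beyond the scatter), and compound 3 reverses it, losing the hydroxymethyl while also widening the ring from five to seven members; no measured step covers the ring widening. Compound 3 is therefore expected to move upward, a 2.5-fold higher number from compound 2 to compound 3 (0.40 log units; beyond the scatter). Compound 3 is estimated at 80 nM, within 35 nM to 200 nM.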

Compound 3, half-maximal inhibitory concentration: 23 nM
Compound 3: middle estimate off by 3.5-fold (0.54 log units), on the high side; measured number below the stated range.
By their numbers in this assay, from the lowest: compounds 3 and 2 (each within the scatter of the next); then compound 1.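

In this assay, a hydroxymethyl group is not required at this position for the lowest numbers seen so far: azepan-1-yl, with no hydrogen-bond donor, cannot be separated from 2-(hydroxymethyl)pyrrolidin-1-yl, at a 1.4-fold lower number from compound 2 to compound 3 (0.14 log units; within the scatter). Ring widening alone, with no hydroxymethyl on either ring, gives a 3.0-fold lower number from compound 1 to compound 3 (0.48 log units; beyond the scatter), so ring size at this position also moves the number beyond the scatter. Nothing available explains either step. From the compounds shown here alone, it remains open where piperidin-1-yl, the six-membered ring, would fall. Also open, going by these compounds, is whether a hydroxymethyl on the azepan-1-yl ring would lower the number further.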